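Fluoro in place of ethyl, repeated on a carboxy core

The source may report more compounds than this note shows. Statements on the series, on what has been measured and on what is new or still open speak of the compounds shown alone.

Compound 1 `CCc1ccc2nc(C(=O)Nc3c(F)cc(-c4cccc(F)c4)cc3F)c(C)c(O)c2c1` gives 17.9% in a functional assay on A-375 cells (Homo sapiens) for antiproliferative activity, read by MTT assay, with a stated time of 24 h, tested at 3.7 ug/mL; a higher number here means a stronger effect of the compound at the concentration tested, a lower number a weaker effect. Compound 2 `Cc1c(C(=O)Nc2c(F)cc(-c3cccc(F)c3)cc2F)nc2ccc(F)cc2c1O` carries the change fluoro in place of ethyl on an aromatic carbon and gives 7.85% in this assay; the step is a number 10.1 percentage points lower from compound 1 to compound 2 (beyond the scatter). Compound 3 `CCc1ccc2nc(C(=O)Nc3c(F)cc(-c4cccc(F)c4)cc3F)c(C)c(C(=O)O)c2c1` differs from compound 1 by carboxy in place of hydroxy on an aromatic carbon, and in this assay compound 3 gives 26.7%, the step being a number 8.8 percentage points higher from compound 1 to compound 3 (within the scatter).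

Compound 4 `Cc1c(C(=O)Nc2c(F)cc(-c3cccc(F)c3)cc2F)nc2ccc(F)cc2c1C(=O)O` is not yet measured. It differs from compound 3 by fluoro in place of ethyl on an aromatic carbon, the same change made from compound 1 to compound 2, at the same place, so that the two cores differ only by carboxy in place of hydroxy on an aromatic carbon.

For compound 4 a step of a number 9.7 percentage points lower from compound 3 to compound 4 (within the scatter) is expected in this assay, resting on the earlier a number 10.1 percentage points lower from compound 1 to compound 2 (beyond the scatter). Compound 4 is thus estimated at 17%, with a likely range from 8% to 26%.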

Compound 4, a percentage reported as inhibition, at one concentration (the size of the read-out at that concentration, not a potency): 24.5%
Compound 4: the middle estimate sits 7.5 percentage points below what was measured; low and high end bracket the measured number.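

Fluoro in place of ethyl on the carboxy core gives a number 2.2 percentage points lower from compound 3 to compound 4 (within the scatter) in this assay, and this step does not differ beyond the scatter from the one on the hydroxy core: the same change on two cores in this assay, a number 10.1 percentage points lower (beyond the scatter) from compound 1 to compound 2 and a number 2.2 percentage points lower (within the scatter) from compound 3 to compound 4, 7.9 percentage points apart, within the scatter of two such steps

Carboxy in place of hydroxy, on the core carrying fluoro, gives a number 16.7 percentage points higher from compound 2 to compound 4 (beyond the scatter), again with no difference beyond the scatter from the step on the core carrying ethyl: the same change on two cores in this assay, a number 8.8 percentage points higher (within the scatter) from compound 1 to compound 3 and a number 16.7 percentage points higher (beyond the scatter) from compound 2 to compound 4, 7.9 percentage points apart, within the scatter of two such steps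

This supports carrying either change between these cores only within the scatter; it does not show that the paired steps are equal, nor that either change would carry to any other core.

Open, on these data alone, is whether a chloro group or a longer chain in place of ethyl would follow the same trend. Also open, as far as these compounds go, is whether an amine in place of hydroxy or carboxy would do so.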